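A few compounds are considered here, and "the series" means these few. Any claim that something is new, unique, unknown or untested is made for them only; others in the source may bear on it.

In a functional assay on the whole organism for inhibition, with Rattus norvegicus as the target, read by paw edema, with stated times of 1 h and 3 h (a lower number here means that less compound is needed, a higher number that more compound is needed for the effect), compound 1 `C/C(=N\OC(C)C(=O)O)c1ccc(Cl)cc1` gives 55 mg/kg and compound 2 `C/C(=N\OCC(=O)OC(C)C)c1ccc(Cl)cc1` gives 50 mg/kg, so compound 2 stands within the scatter of compound 1. Compound 3 `CNC(=O)CO/N=C(\C)c1ccc(Cl)cc1` has not yet been measured. It carries methylamino in place of isopropoxy on a carbonyl carbon. Within the data shown here, no measured pair shows this change, so the data give no direct guide to it. The expected step is a slightly higher number, not beyond the scatter: a 1.2-fold higher number from compound 2 to compound 3 (0.08 log units; within the scatter). In this assay the estimated value for compound 3 is 60 mg/kg, with a range from 25 mg/kg to 140 mg/kg.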

Compound 3, dose for half-maximal effect: 70 mg/kg
The estimate for compound 3 lay 1.2-fold (0.07 log units) below the measured number; the range from low to high includes it.
By their numbers in this assay, from the lowest: compounds 2, 1 and 3 (each within the scatter of the next).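

In this assay, among these compounds, methylamino in place of isopropoxy on a carbonyl carbon gives a 1.4-fold higher number from compound 2 to compound 3 (0.15 log units; within the scatter) as the first reading of this change, so the exchange leaves the dose within the usual spread of the assay. Compound 3 also sets (methylcarbamoyl)methyl in place of 1-carboxyethyl on an oxygen, with a 1.3-fold higher number from compound 1 to compound 3 (0.10 log units; within the scatter) as the result, and none of the three side chains separates from the others. Nothing available accounts for these small steps. Going by these compounds, whether dimethylamino, a longer chain on the amide or a primary amide at this carbonyl carbon would move the dose beyond the scatter stays open.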